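A longer chlorinated chain on compound 3

The source may hold more compounds than are shown below. What is called first, only, known or untested is meant among the compounds shown, and "the series" means these compounds.

In a functional assay on KYSE-450 cells (Homo sapiens) for inhibition, read by MTT assay, with a stated time of 48 h (on this read-out lower numbers stand for stronger inhibition and higher numbers for weaker inhibition), compound 1 `C#CC(=O)N(Cc1ccc(OC)c(O)c1)c1cc(OC)c(OC)c(OC)c1` gives 570 nM, compound 2 `COc1ccc(CN(C(=O)CCl)c2cc(OC)c(OC)c(OC)c2)cc1O` gives 210 nM and compound 3 `COc1ccc(CN(C(=O)CCCl)c2cc(OC)c(OC)c(OC)c2)cc1O` gives 110 nM. The data show a 5.2-fold lower number from compound 1 to compound 3 (0.71 log units; beyond the scatter), beyond the scatter, but a 1.9-fold lower number from compound 2 to compound 3 (0.28 log units; within the scatter), within it, so compound 3 cannot be ranked against compound 2. Compound 4 `COc1ccc(CN(C(=O)CCCCCl)c2cc(OC)c(OC)c(OC)c2)cc1O` differs from compound 3 by 2-chloroethyl in place of chloro on a saturated chain carbon, two bonds along the chain from a carbonyl carbon. Going by the values given here, the closest precedent is the chain lengthening in a 1.9-fold lower number from compound 2 to compound 3 (0.28 log units; within the scatter), so no step beyond the scatter is expected in this assay. The expected change is a 1.4-fold higher number from compound 3 to compound 4 (0.13 log units; within the scatter). Compound 4 is estimated at 150 nM, with an expected range of 60 nM to 400 nM.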

Compound 4, half-maximal inhibitory concentration: 770 nM
Beside the measured number, compound 4's estimate is 5.1-fold (0.71 log units) below it; the whole stated range lies below it.
By their numbers in this assay, from the lowest: compounds 3 and 2 (each within the scatter of the next); then compounds 1 and 4 (each within the scatter of the next).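

Chain length at this position now clearly matters: compounds 2 and 3 could not be separated, yet the 4-chlorobutyl group on the carbonyl gives a 7.0-fold higher number from compound 3 to compound 4 (0.85 log units; beyond the scatter) and a 3.7-fold higher number from compound 2 to compound 4 (0.56 log units; beyond the scatter). Inhibition therefore weakens when the chain reaches this length, rather than holding steady or improving. The gain that the two shorter chlorinated chains showed over the ethynyl group is also gone, with a 1.4-fold higher number from compound 1 to compound 4 (0.13 log units; within the scatter), so compound 4 cannot be told apart from compound 1.

No measurement offered here explains this drop. Still open, on these data alone, is whether a 3-chloropropyl group on the carbonyl would behave like compound 3 or compound 4, and whether an amine in place of the chlorine would restore inhibition.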